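A few compounds are considered here, and "the series" means these few. Any claim that something is new, unique, unknown or untested is made for them only; others in the source may bear on it.

Working notes on the series. Compound 1 `Cn1nnc(-c2sc(-c3cccc(F)c3)nc2O)n1` is measured in an assay on HEK293 cells for inhibition of transient receptor potential cation channel subfamily M member 8 (Homo sapiens), read by FLIPR, with stated times of 5 min and 3 min (on this read-out higher numbers stand for weaker inhibition and lower numbers for stronger inhibition), at 214 nM. Among the numbers on hand compound 1 stands highest of the two; its nearest neighbour is compound 3 `CON(C)C(=O)c1sc(-c2ccccc2O)nc1O`, which in this assay gives 66 nM, a gap that lies beyond the usual scatter. Compound 2 `CCOC(=O)c1oc(-c2ccc(Cl)cc2)nc1O` gives in this assay only a limit, > 100000 nM. This is the limit of > 100000 nM in this assay, at which 1 of the 3 values shown sits.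

Compound 4 `CON(C)C(=O)c1sc(-c2cccc(F)c2)nc1O` has not yet been measured in this assay. Going from compound 1 to compound 4 the change is methoxy(methyl)carbamoyl in place of 2-methyl-2H-tetrazol-5-yl on an aromatic carbon. Among the measured compounds shown here, no pair of measured compounds differs in one place only, so the size of this step is not anchored by a measured step. Compound 3 carries the same methoxy(methyl)carbamoyl on the shared core and sits at the lower of the two numbers, but it differs from compound 1 in a second place as well, so its value shows only that the carbamoyl is compatible with strong inhibition. A step toward stronger inhibition is expected, of a size not clearly beyond the scatter, a 1.8-fold lower number from compound 1 to compound 4 (0.25 log units; within the scatter). Compound 4 is accordingly estimated in this assay at 120 nM, with a range from 40 nM to 400 nM.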

Compound 4, half-maximal inhibitory concentration: 96 nM
Beside the measured number, compound 4's estimate is 1.3-fold (0.10 log units) above it; low and high end bracket the measured number.
By their numbers in this assay, from the lowest: compounds 3 and 4 (each within the scatter of the next); then compound 1. At a limit, above all of these: compound 2.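

Working notes, continued. In this assay, among the compounds shown here, the replacement on the aromatic carbon next to the ring sulfur gives the first measured step, a 2.2-fold lower number from compound 1 to compound 4 (0.35 log units; beyond the scatter), with methoxy(methyl)carbamoyl in place of 2-methyl-2H-tetrazol-5-yl and the rest of the structure unchanged. This step is modest, but it shows directly what compound 3 could only suggest: on this core and at this position, the open-chain methoxy(methyl)carbamoyl gives a lower number than the five-membered aromatic ring with 4 hetero atoms, so that ring is not required here for inhibition at this level. Nothing on hand bears on why the number falls with this change.

The compounds shown leave open whether the same step would appear with the other aryl group on the shared core, since the single step here comes from one pair. They also leave open which part of the methoxy(methyl)carbamoyl matters, and how a plain dimethylamide, a primary carboxamide or a carboxylic acid would read at this position.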